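The compounds below may be only part of what the source reports. "The series", "measured", "known", "first", "only" and "open" are said of these compounds alone.

Of the compounds shown here, three built on one shared core have been measured in an ADME assay on HEK-293T cells (Homo sapiens) for cytotoxicity, read by MTT assay, with a stated time of 24 h; on this read-out lower numbers stand for higher toxicity in this test and higher numbers for lower toxicity in this test: compound 1 `Cc1cccc(C(=O)n2c(-c3cn(-c4ccccc4)nc3-c3ccc(C(F)(F)F)cc3)nc3ccccc32)c1` gives 154000 nM, compound 2 `Cc1ccc(C(=O)n2c(-c3cn(-c4ccccc4)nc3-c3ccc(C(F)(F)F)cc3)nc3ccccc32)cc1` gives 169000 nM, and compound 3 `Cc1ccc(C(=O)n2c(-c3cn(-c4ccccc4)nc3-c3ccc(F)cc3)nc3ccccc32)cc1` gives 178000 nM. Compound 3 stands alongside the other two, parted from each by no more than the usual scatter. Compound 4 `O=C(c1ccncc1)n1c(-c2cn(-c3ccccc3)nc2-c2ccc(F)cc2)nc2ccccc21` differs from compound 3 in one place: pyridin-4-yl in place of 4-methylphenyl on a carbonyl carbon. Going by the values given here, of the measured steps, a 1.1-fold higher number from compound 1 to compound 2 (0.04 log units; within the scatter) also falls on the carbonyl carbon, whereas a 1.1-fold higher number from compound 2 to compound 3 (0.02 log units; within the scatter) lies at another position; no measured pair swaps 4-methylphenyl for pyridin-4-yl. Because a 1.1-fold higher number from compound 1 to compound 2 (0.04 log units; within the scatter) stayed within the scatter, the step of a 1.0-fold lower number from compound 3 to compound 4 (0.02 log units; within the scatter) is likewise expected to stay within it. Compound 4 is therefore estimated at 170000 nM, with a range from 85000 nM to 340000 nM.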

Compound 4, half-maximal cytotoxic concentration: 151000 nM
Compound 4: the middle estimate sits 1.1-fold (0.05 log units) above what was measured; the range from low to high includes it.
By their numbers in this assay, from the lowest: compounds 4, 1, 2 and 3 (each within the scatter of the next).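

Putting pyridin-4-yl in place of 4-methylphenyl on the carbonyl carbon gave, in this assay, a 1.2-fold lower number from compound 3 to compound 4 (0.07 log units; within the scatter), so the number held within the scatter. The earlier step at this carbon only shifted the methyl on a carbon-only ring, whereas here the ring itself gains a hetero atom and a hydrogen-bond acceptor. No measurement on hand offers an explanation for this result. Still open, going by these compounds, is whether an amine or a carboxylic acid on this ring, or a longer alkyl chain in its place, would keep the number in this range. Also open, on these data alone, is whether pyridin-4-yl would do the same with trifluoromethyl in place of fluoro.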